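From fluoro to isopropoxy on a shared core

This account rests on a few compounds, and the source may have more. Where it says the series, first, only, none or still open, it means among the compounds named here.

Measured in an ADME assay on L132 cells (Homo sapiens) for cytotoxicity, read by MTT assay, with a stated time of 72 h; on this read-out lower numbers stand for stronger inhibition and higher numbers for weaker inhibition:
Compound 1 `COc1ccc(C2=C(c3cc(OC)c(OC)c(OC)c3)C(=O)C(O[SiH2]C(C)(C)C)C2)cc1OC(C)C`: 7 ug/mL
Compound 2 `COc1ccc(C2=C(c3cc(OC)c(OC)c(OC)c3)C(=O)C(O)C2)cc1F`: < 1 ug/mL (a limit)

For compound 2, the reading of < 1 ug/mL is a limit of the assay and not a number. Compound 3 `COc1ccc(C2=C(c3cc(OC)c(OC)c(OC)c3)C(=O)C(O)C2)cc1OC(C)C` has isopropoxy in place of fluoro on an aromatic carbon, ortho to a methoxy group: isopropoxy in place of fluoro on an aromatic carbon. Going by the values given here, no measured step isolates this change in this assay. Compound 1, which also carries isopropoxy, gives 7 ug/mL, so weaker inhibition is expected. The expected change is an at least 2.0-fold higher number from compound 2 to compound 3 (0.30 log units; that floor lies within the scatter). Compound 3 is estimated at 2 ug/mL, within a range of 0.4 ug/mL to 8 ug/mL.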

Compound 3, half-maximal inhibitory concentration: > 100 ug/mL
Compound 3 ended at the assay's limit; the forecaster's own chance of this, stated with the estimate: 30%; middle value at least 50-fold (1.69 log units) away from the limit.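

In this assay, the aromatic carbon ortho to a methoxy group proves highly sensitive to this change: isopropoxy in place of fluoro gives an at least 100-fold higher number from compound 2 to compound 3 (2.00 log units; beyond the scatter). Compound 3, at > 100 ug/mL, stands at a limit of the assay and not at a number. With isopropoxy held constant, the oxygen on a saturated carbon also matters: a hydrogen atom in place of the group of 5 heavy atoms gives an at least 14-fold higher number from compound 1 to compound 3 (1.15 log units; beyond the scatter).

As far as these compounds go, how far either step truly extends remains open. So does whether an amine or a longer alkoxy chain on that aromatic carbon would read closer to compound 2 or to compound 3.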